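The source may hold more compounds than are shown below. What is called first, only, known or untested is meant among the compounds shown, and "the series" means these compounds.

Measured compounds:
compound 1, `COc1ccc(-c2nn(-c3ccccc3)cc2C(Nc2nc3ccccc3s2)c2c(O)ccc3ccccc23)cc1`: 17500 nM
compound 2, `O=[N+]([O-])c1ccc(-c2nn(-c3ccccc3)cc2C(Nc2nc3ccccc3s2)c2c(O)ccc3ccccc23)cc1`: 14700 nM
compound 3, `O=[N+]([O-])c1cccc(-c2nn(-c3ccccc3)cc2C(Nc2nc3ccc(Cl)cc3s2)c2c(O)ccc3ccccc23)c1`: 19700 nM

All three were tested in a functional assay on MCF7 cells (Homo sapiens) for antiproliferative activity, read by MTT assay, with a stated time of 48 h; on this read-out higher numbers stand for weaker inhibition and lower numbers for stronger inhibition. Compound 2 gives 14700 nM and compound 1 gives 17500 nM; these two share a core and differ in one place, described as methoxy in place of nitro on an aromatic carbon. The step that this change made is a 1.2-fold higher number from compound 2 to compound 1 (0.08 log units; within the scatter), so the two values cannot be told apart.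

Compound 3 gives 19700 nM in this assay. Its core is not the same as that of compound 2, and the difference between the two cores is not broken down here. Compound 4, `COc1cccc(-c2nn(-c3ccccc3)cc2C(Nc2nc3ccc(Cl)cc3s2)c2c(O)ccc3ccccc23)c1`, is not yet measured. It differs from compound 3 in one place, described as methoxy in place of nitro on an aromatic carbon. Among the compounds with values here, this is the same kind of change as the one from compound 2 to compound 1, but not the same: in the earlier pair the group sat para to a large group, here it sits meta to a large group.

Since the earlier step, a 1.2-fold higher number from compound 2 to compound 1 (0.08 log units; within the scatter), lay within the scatter, a step of similar size is expected from compound 3 to compound 4 in this assay, namely a 1.1-fold higher number from compound 3 to compound 4 (0.03 log units; within the scatter), resting on compound 3 at 19700 nM as the starting point. Compound 4 is therefore estimated at 21000 nM, with a range from 9000 nM to 48000 nM.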

Compound 4, half-maximal inhibitory concentration: 36000 nM
The estimate for compound 4 lay 1.7-fold (0.23 log units) below the measured number, within the range that was stated.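

In this assay, putting methoxy in place of nitro, the change from 3-nitrophenyl to 3-methoxyphenyl, gives a 1.8-fold higher number from compound 3 to compound 4 (0.26 log units; within the scatter), so this pair cannot be told apart any more than the earlier one could. Set beside that earlier pair, the change behaves alike on the two cores, with no difference that stands out from ordinary measurement noise: the same change on two cores in this assay, a 1.2-fold higher number (0.08 log units; within the scatter) from compound 2 to compound 1 and a 1.8-fold higher number (0.26 log units; within the scatter) from compound 3 to compound 4, 1.5-fold (0.19 log units) apart, within the scatter of two such steps. This shows that, in these two pairs, swapping nitro for methoxy made no change that can be distinguished from scatter, but it does not show that the swap is without effect on every core in the series, and two pairs that differ both in their core and in where the group sits cannot tell those two influences apart.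

What the compounds shown leave open is how a group of another kind on this aromatic ring, such as an amine, a carboxylic acid or a longer chain like butoxy, would affect the number in this assay. They also leave open whether nitro and methoxy would give the same result if each were moved to another place on the ring while the core stayed fixed.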